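The source may report more compounds than this note shows. Statements on the series, on what has been measured and on what is new or still open speak of the compounds shown alone.

Compound 1 `COc1ccccc1Oc1c(N)nc(-c2cccc(C)c2)nc1Cl` gives 11200 nM in a toxicity assay on HaCaT cells (Homo sapiens) for cytotoxicity, read by CCK-8 assay, with a stated time of 24 h (on this read-out higher numbers stand for lower toxicity in this test and lower numbers for higher toxicity in this test), and compound 2 `COc1cccc(-c2nc(N)c(Oc3ccccc3OC)c(Cl)n2)c1` gives 14000 nM, which makes a 1.3-fold higher number from compound 1 to compound 2 (0.10 log units; within the scatter). Compound 3 `COc1ccccc1Oc1c(N)nc(-c2ccccc2F)nc1Cl` gives > 80000 nM, which is a limit and not a number. Compound 4 `COc1ccccc1Oc1c(N)nc(-c2ccc(F)cc2)nc1Cl` has 4-fluorophenyl in place of 2-fluorophenyl on an aromatic carbon. Two measured steps change the group at this same place: an at least 7.1-fold higher number from compound 1 to compound 3 (0.85 log units; beyond the scatter), and an at least 5.7-fold higher number from compound 2 to compound 3 (0.75 log units; beyond the scatter). Going by these compounds, both lie beyond the scatter and both end at a limit, so their full size is unknown. Neither of them moves only the fluorine, so a smaller step is expected here, towards a lower number. The expected change is an at least 2.0-fold lower number from compound 3 to compound 4 (0.30 log units; that floor lies within the scatter). Compound 4 is estimated at 40000 nM, within an expected range of 15000 nM to 100000 nM.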

Compound 4, half-maximal cytotoxic concentration: 42600 nM
Compound 4: middle estimate off by 1.1-fold (0.03 log units), on the low side; measured number inside the range.
By their numbers in this assay, from the lowest: compounds 1 and 2 (each within the scatter of the next); then compound 4. At a limit, above all of these: compound 3.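

In this assay, a fluorophenyl group at this position now has a true number, and the higher reading over the methyl and methoxy compounds no longer rests on a limit alone: a 3.0-fold higher number from compound 2 to compound 4 (0.48 log units; beyond the scatter) and a 3.8-fold higher number from compound 1 to compound 4 (0.58 log units; beyond the scatter). Moving only the fluorine gives an at least 1.8-fold lower number from compound 3 to compound 4 (0.27 log units; that floor lies within the scatter), so it remains unsettled whether its place on the ring matters. Compound 3 carries a limit and not a number: the limit of > 80000 nM in this assay, at which 1 of the 4 values shown sits.

Still open, going by these compounds, is how 3-fluorophenyl would read here, with the fluorine at the ring position held by methyl and methoxy in compounds 1 and 2. Also open, on these data alone, is whether plain phenyl, or a phenyl carrying an amine or a carboxylic acid, would keep the higher number.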